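From isopropyl to 3-methoxyphenyl on an aromatic nitrogen

The source may report more compounds than this note shows. Statements on the series, on what has been measured and on what is new or still open speak of the compounds shown alone.

Swapping a single group can decide whether a compound slows the growth of cancer cells at all. In a functional assay on HT-29 cells (Homo sapiens) for antiproliferative activity, read by MTT assay, with a stated time of 72 h (a higher number here means a weaker inhibitor, a lower number a stronger inhibitor), compound 1 `COc1cc(-c2nccn2C(C)C)cc(OC)c1OC` reads > 100000 nM as its result, which is a limit of the assay and not a number. In this assay compound 2 `COc1ccc(-n2ccnc2-c2cc(OC)c(OC)c(OC)c2)cc1[N+](=O)[O-]` gives 600 nM and compound 3 `COc1cc(-c2nccn2-c2ccc3[nH]ccc3c2)cc(OC)c1OC` gives 9100 nM as real numbers, and both carry a group containing a six-membered aromatic ring on that same nitrogen.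

Compound 4 `COc1cccc(-n2ccnc2-c2cc(OC)c(OC)c(OC)c2)c1` keeps the core of compound 1 and changes one place: 3-methoxyphenyl stands in place of isopropyl on an aromatic nitrogen (3-methoxyphenyl in place of isopropyl on an aromatic nitrogen). Within the data shown here, no pair of measured compounds differs in just one place, so the expectation rests on the two numbers from compound 2 and compound 3 alone. In this assay the expected step (an at least 33-fold lower number from compound 1 to compound 4 (1.52 log units; beyond the scatter)) is large and runs toward a stronger inhibitor, well beyond the usual scatter. Its size stays rough, as the starting point is only a limit. For compound 4 the estimated value is 3000 nM with an expected range from 400 nM to 25000 nM in this assay once it is measured.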

Compound 4, half-maximal inhibitory concentration: 18900 nM
For compound 4 the middle estimate is 6.3-fold (0.80 log units) below the measured one, and the stated range covers the measured number.
By their numbers in this assay, from the lowest: compound 2; then compound 3; then compound 4. At a limit, above all of these: compound 1.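

Among these compounds, compound 1 and compound 4 differ in one place only, so this pair gives the first direct reading of what the group on this aromatic nitrogen does, with the rest of the core held fixed. In this assay, 3-methoxyphenyl in place of isopropyl gives an at least 5.2-fold lower number from compound 1 to compound 4 (0.72 log units; beyond the scatter), a change that lies beyond the usual scatter and turns a result with no real number into one, as compound 4 gives 18900 nM. The value for compound 1 is a limit of the assay and not a number, so the true step could be larger than this figure, and its size remains a lower bound because of that limit: the limit of > 100000 nM in this assay, at which 1 of the 4 values shown sits.

The step cannot yet be divided between the six-membered aromatic ring and the methoxy group on it, as the compounds shown do not separate the two. They also leave open how an unsubstituted phenyl, a cyclohexyl ring or a longer chain such as n-butyl would read on the same nitrogen.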